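The compounds below may be only part of what the source reports. "The series", "measured", "known", "first", "only" and "open" are said of these compounds alone.

Compound 1, with the structure `O=C(CN1CCN(c2cccc(F)c2)CC1)Nc1nc2c(s1)CCCC2`, is recorded as "not determined" (no result reported) in a physicochemical assay for lipophilicity, in phosphate buffer, measured as octanol-water partition, at pH 7.4 (on this read-out higher numbers stand for higher lipophilicity and lower numbers for lower lipophilicity), so it has no single number to stand on. Two relatives do. Compound 2, `Cc1nc(NC(=O)CN2CCN(c3ccc(F)cc3)CC2)sc1C`, gives 3.7 in this assay, and compound 3, `O=C(CN1CCN(c2ccc(F)cc2)CC1)Nc1nc2c(o1)CCCC2`, gives 3. Neither pair, compound 2 against compound 3 or either against compound 1, differs in only one place, so their values show only the band in which compounds of this shape have so far appeared.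

Compound 4, `O=C(CN1CCN(C2CCCCC2)CC1)Nc1nc2c(s1)CCCC2`, differs from compound 1 in one place: cyclohexyl in place of 3-fluorophenyl on an amine nitrogen in a ring. Going by the values given here, no measured pair shows this change, so its effect in this assay has to be guessed from the general character of the group names alone. A lower value for compound 4 than compound 1 would have had is expected, and the step is expected to be larger than the scatter of the measurement. Compound 4 is therefore expected to give 2.4 in this assay, within a range of 1.4 to 3.4.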

Compound 4, distribution coefficient: 3
The estimate for compound 4 lay 0.60 log units below the measured number, and the stated range covers the measured number.
By their numbers in this assay, from the lowest: compounds 3 and 4 (each within the scatter of the next); then compound 2.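

Going by these compounds alone, compound 1 stands at "not determined" (no result reported) in this assay and compound 4 gives 3 there, so no step from 3-fluorophenyl to cyclohexyl can be read between them. The compounds shown leave open how far, and in which direction, this change moves the read-out on the shared core. No measured finding bears on the value of compound 4.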